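Methyl on the core, tested on a naphthyl analogue

This account rests on a few compounds, and the source may have more. Where it says the series, first, only, none or still open, it means among the compounds named here.

In a functional assay on CAKI-1 cells (Homo sapiens) for antiproliferative activity (on this read-out lower numbers stand for stronger inhibition of growth and higher numbers for weaker inhibition of growth), compound 1 `Cc1ccc2c(O)cc(-c3cccc(Cl)c3)nc2n1` gives 41.7 nM. Compound 2 `Cc1cc(C)c2c(O)cc(-c3cccc(Cl)c3)nc2n1` carries the change methyl in place of hydrogen on an aromatic carbon on the same core and gives 204 nM in this assay; the step of a 4.9-fold higher number from compound 1 to compound 2 (0.69 log units; beyond the scatter). Compound 3 `Cc1ccc2c(O)cc(-c3ccc4ccccc4c3)nc2n1` bears a different aromatic group on its core; the difference between the two cores is not broken down here. In this assay compound 3 gives 5370 nM, the highest of the three numbers, well separated from the other two.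

Compound 4 `Cc1cc(C)c2c(O)cc(-c3ccc4ccccc4c3)nc2n1` is the unmeasured member of the set. It arises from compound 3 through the change (methyl in place of hydrogen on an aromatic carbon), which is the same change as that from compound 1 to compound 2: the atom that leaves, the group that enters and the place on the core are described in identical words. Among the compounds shown this change occurs twice.

Among the compounds with values here, the expectation for compound 4 rests on the single measured example of the change. Because a 4.9-fold higher number from compound 1 to compound 2 (0.69 log units; beyond the scatter), the step is expected to be a 3.7-fold higher number from compound 3 to compound 4 (0.57 log units; beyond the scatter), of a similar size, with the caveat that compound 3 already stands far above compound 1 and compound 2 in this assay, so the number may run close to the edge of what the assay reports. The estimate for compound 4 in this assay is 20000 nM, expected to fall between 6000 nM and 60000 nM.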

Compound 4, concentration for 50% growth inhibition: 51300 nM
For compound 4 the middle estimate is 2.6-fold (0.41 log units) below the measured one, and the stated range covers the measured number.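

Carried to the second core, methyl in place of hydrogen on an aromatic carbon again goes with weaker inhibition of growth in this assay, with a 9.6-fold higher number from compound 3 to compound 4 (0.98 log units; beyond the scatter). Set beside the earlier step, the new one runs in the same direction, and the gap between the two is no larger than repeated measurements could produce: the same change on two cores in this assay, a 4.9-fold higher number (0.69 log units; beyond the scatter) from compound 1 to compound 2 and a 9.6-fold higher number (0.98 log units; beyond the scatter) from compound 3 to compound 4, 2.0-fold (0.29 log units) apart, within the scatter of two such steps. The change therefore carries over from the core of compound 1 to the core of compound 3 in this pair of examples, and the steps should not be read as differing in size between the two cores, but two examples do not establish a rule for other cores in the series and do not explain why the number rises.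

The compounds shown leave open whether an ethyl group, a fluorine atom or an amine on the same aromatic carbon would shift the number as methyl does. They also leave open whether the methyl step would keep its direction and size on a core carrying a different aromatic group from the two seen here, or in any other cell line.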